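The source may report more compounds than this note shows. Statements on the series, on what has been measured and on what is new or still open speak of the compounds shown alone.

Compound 1, `COc1cc2ncnc(Nc3cccc(C(F)(F)F)c3)c2cc1OCCCSc1nc2ccccc2s1`, is tested in a functional assay on MCF7 cells (Homo sapiens) for cytotoxicity, read by MTT assay, with a stated time of 24 h (on this read-out lower numbers stand for stronger inhibition and higher numbers for weaker inhibition), where compound 1 gives 4050 nM. Compound 2, `CCc1cc(Br)ccc1Nc1ncnc2cc(OC)c(OCCCSc3nc4ccccc4s3)cc12`, carries 4-bromo-2-ethylphenyl in place of 3-(trifluoromethyl)phenyl on a nitrogen on an aromatic ring, and in this assay compound 2 gives 5870 nM; the change makes a 1.4-fold higher number from compound 1 to compound 2 (0.16 log units; within the scatter). Compound 3, `CCCCc1nc(Cl)c(C=O)n1CCCOc1cc2c(Nc3cccc(C(F)(F)F)c3)ncnc2cc1OC`, rests on a different core: its difference from compound 1 is 2-butyl-4-chloro-5-formyl-1H-imidazol-1-yl in place of (1,3-benzothiazol-2-yl)sulfanyl on a saturated chain carbon, three bonds along the chain from an oxygen on an aromatic ring, and in this assay compound 3 gives 3510 nM, which is a 1.2-fold lower number from compound 1 to compound 3 (0.06 log units; within the scatter). The two values of compound 1 and compound 3 therefore sit close together, as do those of compound 2 and compound 3. Compound 4, `CCCCc1nc(Cl)c(C=O)n1CCCOc1cc2c(Nc3ccc(Br)cc3CC)ncnc2cc1OC`, has not yet been measured. It differs from compound 3 by 4-bromo-2-ethylphenyl in place of 3-(trifluoromethyl)phenyl on a nitrogen on an aromatic ring, which is the same change as that made from compound 1 to compound 2, at the same kind of position. Because that earlier change gave a 1.4-fold higher number from compound 1 to compound 2 (0.16 log units; within the scatter), the step from compound 3 to compound 4 is expected to be a 1.4-fold higher number from compound 3 to compound 4 (0.14 log units; within the scatter), of about the same size and direction. On that basis compound 4 is expected to give 4900 nM in this assay, with an estimated range from 2500 nM to 9500 nM.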

Compound 4, half-maximal inhibitory concentration: 6560 nM
Estimate against measurement, compound 4: 1.3-fold (0.13 log units) below; low and high end bracket the measured number.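

In this assay, placing 4-bromo-2-ethylphenyl in place of 3-(trifluoromethyl)phenyl on the nitrogen gives a 1.9-fold higher number from compound 3 to compound 4 (0.27 log units; within the scatter), and this step agrees with its earlier counterpart: the same change on two cores in this assay, a 1.4-fold higher number (0.16 log units; within the scatter) from compound 1 to compound 2 and a 1.9-fold higher number (0.27 log units; within the scatter) from compound 3 to compound 4, 1.3-fold (0.11 log units) apart, within the scatter of two such steps. Placing 2-butyl-4-chloro-5-formyl-1H-imidazol-1-yl in place of (1,3-benzothiazol-2-yl)sulfanyl on the saturated chain gives a 1.1-fold higher number from compound 2 to compound 4 (0.05 log units; within the scatter), and this step also agrees with its counterpart: the same change on two cores in this assay, a 1.2-fold lower number (0.06 log units; within the scatter) from compound 1 to compound 3 and a 1.1-fold higher number (0.05 log units; within the scatter) from compound 2 to compound 4, 1.3-fold (0.11 log units) apart, within the scatter of two such steps. For the compounds shown here, all of these steps lie within the scatter, so the agreement shows only that neither change moved the number beyond the scatter on either core; it does not show that a clear effect would carry from one core to another, and it rests on just four compounds.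

The compounds shown leave open whether a step of clear size exists in this series at all, for example with an amine or a carboxylic acid on the saturated chain, or with a longer chain. They also leave open whether a plain phenyl on the nitrogen would behave in the same way on both cores.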